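The source may hold more compounds than are shown below. What is called first, only, known or untested is meant among the compounds shown, and "the series" means these compounds.

Working notes on the series. For the measured compounds named here, compound 2 `O=C(/C=C\Nc1ccc(Cl)cc1)c1cn(-c2ccccc2)nc1-c1ccc(F)cc1` holds the only plain number so far: in a functional assay on U-87MG ATCC cells (Homo sapiens) for antiproliferative activity, read by MTT assay, with a stated time of 48 h (a lower number here means a stronger inhibitor, a higher number a weaker inhibitor), compound 2 gives 8900 nM. Compound 1 `O=C(/C=C\Nc1ccc(C(F)(F)F)cc1)c1cn(-c2ccccc2)nc1-c1ccccc1`, which also carries a trifluoromethyl, returns in this assay only a limit of the assay, > 50000 nM. Compound 3 `O=C(/C=C\Nc1ccc(C(F)(F)F)cc1)c1cn(-c2ccccc2)nc1-c1ccc(F)cc1` remains to be measured. The change from compound 2 is trifluoromethyl in place of chloro on an aromatic carbon. Going by the values given here, no measured step of this kind exists here, so the expectation rests on compound 1 and leans weaker due to the limit of > 50000 nM in this assay, at which 1 of the 2 values shown sits; the expected step is a 2.8-fold higher number from compound 2 to compound 3 (0.45 log units; beyond the scatter), beyond the scatter. Compound 3 is estimated at 25000 nM, between 8000 nM and 80000 nM.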

Compound 3, half-maximal inhibitory concentration: > 50000 nM
Compound 3 was reported as a limit (the forecaster's own chance of this, stated with the estimate: 45%); middle value at least 2.0-fold (0.30 log units) away from the limit.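

In this assay, for the compounds shown here, trifluoromethyl in place of chloro on this aromatic carbon gives an at least 5.6-fold higher number from compound 2 to compound 3 (0.74 log units; beyond the scatter), the first readable step at this position, and it sets only a minimum for the change. The step from compound 1 to compound 3, fluoro in place of hydrogen, cannot be read, since both compounds are reported as limits. Plain numbers are now the exception in the series: the limit of > 50000 nM in this assay, at which 2 of the 3 values shown sit.

From the compounds shown here alone, whether a methoxy, an amine or a nitrile at this carbon gives a plain number stays open. Going by these compounds, the effect of fluoro in place of hydrogen with chloro at this carbon also stays open.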